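A few compounds are considered here, and "the series" means these few. Any claim that something is new, unique, unknown or untested is made for them only; others in the source may bear on it.

Compound 1 `Cc1ccc(OCC(=O)N(Cc2cccs2)CC(C)C)cc1` gives 900 nM in an assay on HEK293 cells for agonist activity at transient receptor potential cation channel subfamily M member 8 (Homo sapiens), read by fluorescence and calcium flux, with a stated time of 15 min; a higher number here means that more compound is needed for the effect, a lower number that less compound is needed.
Compound 2 `Cc1ccc(OCC(=O)N(Cc2cccs2)C2CCCCC2)cc1` gives 40000 nM in this assay.
Compound 3 `Cc1ccc(OCC(=O)N(Cc2cccs2)c2nccn2C)cc1` gives 1790 nM in this assay.

Among these three, compound 3 sits close to compound 1, the two differing by a 2.0-fold higher number from compound 1 to compound 3 (0.30 log units; within the scatter), and far from compound 2, which lies a 22-fold lower number from compound 2 to compound 3 (1.35 log units; beyond the scatter) away. The shared core is kept in all of them; only the group on the amide-type nitrogen changes.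

Compound 4 `Cc1ccc(OCC(=O)N(Cc2cccs2)c2ccccc2)cc1` carries the next change: phenyl in place of 1-methyl-1H-imidazol-2-yl on an amide-type nitrogen. The steps measured so far bear on it only loosely. Replacing isobutyl by cyclohexyl gave a 44-fold higher number from compound 1 to compound 2 (1.65 log units; beyond the scatter), replacing isobutyl by the imidazolyl ring gave a 2.0-fold higher number from compound 1 to compound 3 (0.30 log units; within the scatter), so a six-membered saturated ring on this nitrogen cost much, whereas a five-membered aromatic ring cost little. Among the compounds with values here, no measured pair swaps one aromatic ring for another, so the size of the present step is not well anchored; a modest change, possibly within the scatter, is expected. For compound 4 the estimate in this assay is 3000 nM, between 800 nM and 12000 nM, which means an expected step of a 1.7-fold higher number from compound 3 to compound 4 (0.22 log units; within the scatter).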

Compound 4, half-maximal effective concentration: 23 nM
Estimate against measurement, compound 4: 130-fold (2.12 log units) above; the whole stated range lies above it.
By their numbers in this assay, from the lowest: compound 4; then compounds 1 and 3 (each within the scatter of the next); then compound 2.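

In this assay the ring on the amide-type nitrogen matters far more than compounds 1 to 3 suggested: phenyl in place of 1-methyl-1H-imidazol-2-yl brings a 78-fold lower number from compound 3 to compound 4 (1.89 log units; beyond the scatter) and shows that two aromatic rings of equal heavy-atom count are not interchangeable at this position. Phenyl also gives a 39-fold lower number from compound 1 to compound 4 (1.59 log units; beyond the scatter) against isobutyl and a 1700-fold lower number from compound 2 to compound 4 (3.24 log units; beyond the scatter) against cyclohexyl, so changes at this one position can move the number strongly in either direction, and compound 4 has the lowest number of the four. Nothing measured here explains why the carbon-only ring differs so sharply from the ring with two nitrogens.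

From the compounds shown here alone, it remains open whether the low number needs an unsubstituted phenyl. A pyridyl ring, a 4-fluorophenyl group or a benzyl group on this nitrogen would test how much of that ring can change.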